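A few compounds are considered here, and "the series" means these few. Any claim that something is new, unique, unknown or untested is made for them only; others in the source may bear on it.

Measured so far:
- compound 1 `Cc1c(-c2ccc(O)c3ncccc23)oc2ccc(O)cc12`: 16.8 10^-6 cm/s
- compound 2 `Oc1ccc2oc(-c3cc(Cl)c(O)c4ncccc34)cc2c1`: 21.4 10^-6 cm/s

Both compounds were tested in an ADME assay for permeability, using PAMPA, with a stated time of 10 h, tested at 100 ug/mL; a higher number here means that the compound crosses the layer faster, a lower number that the compound crosses the layer more slowly. For the measured compounds named here, compound 2 gives 21.4 10^-6 cm/s and compound 1 gives 16.8 10^-6 cm/s, and these two numbers lie within the usual scatter of each other, so compound 2 cannot be separated from its only neighbour on this scale.

The next compound, compound 3 `Cc1c(-c2cc(Cl)c(O)c3ncccc23)oc2ccc(O)cc12`, is reached from compound 2 by a single change: methyl in place of hydrogen on an aromatic carbon. This is a methyl in place of hydrogen on an aromatic carbon. Going by the values given here, no pair of measured compounds differs by this change alone, so the data give no direct measure of it. Compound 1 also carries this methyl, however, and it gives 16.8 10^-6 cm/s in this assay. On that basis, no step beyond the scatter is expected, and any drift would be expected towards a slightly lower number. The estimate amounts to a 1.1-fold lower number from compound 2 to compound 3 (0.05 log units; within the scatter), an expected step of modest size. For compound 3 the estimated value is 19 10^-6 cm/s, with an expected range from 10 10^-6 cm/s to 36 10^-6 cm/s.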

Compound 3, apparent permeability: 3.5 10^-6 cm/s
The estimate for compound 3 lay 5.4-fold (0.73 log units) above the measured number; the whole stated range lies above it.
By their numbers in this assay, from the lowest: compound 3; then compounds 1 and 2 (each within the scatter of the next).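

In this assay, the methyl on an aromatic carbon of the five-membered aromatic ring with 1 oxygen proves able to move the number well beyond the scatter, with a 6.1-fold lower number from compound 2 to compound 3 (0.79 log units; beyond the scatter) in the presence of the chloro. For the compounds shown here, the chloro also has a clear effect where the methyl is already in place, with a 4.8-fold lower number from compound 1 to compound 3 (0.68 log units; beyond the scatter), so the two steps together set compound 3 apart from both compounds that carry only one of these two groups, and the effect of the methyl at this position cannot be read from compound 1 alone. No measurement shown here offers an explanation for this drop.

As far as these compounds go, the methyl step is known only with the chloro present, so its size without the chloro remains open, as does the size of the chloro step without the methyl. From the compounds shown here alone, it is also open whether an ethyl chain or an amine on this same aromatic carbon would give a step like that of the methyl, or whether any such step depends on the chloro too.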